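The source may report more compounds than this note shows. Statements on the series, on what has been measured and on what is new or still open speak of the compounds shown alone.

The measured compounds:
compound 1, `CCCCCCCC/C=C/CCCCCCCC(=O)Nc1ccccc1CC`, 1200 nM
compound 2, `CCCCCCCC/C=C/CCCCCCCC(=O)Nc1cccc(C(=O)OC)c1C`, a limit of the assay, > 5000 nM
compound 3, `CCCCCCCC/C=C/CCCCCCCC(=O)Nc1cccc(C)c1[N+](=O)[O-]`, 12000 nM

The three compounds share one core and were examined in an assay on microsomes from intestine for inhibition of acyl-CoA:cholesterol acyltransferase (Oryctolagus cuniculus); a lower number here means a stronger inhibitor, a higher number a weaker inhibitor. Compound 1 gives the lowest of the two numbers in this assay; the other number lies one modest step away, a 10-fold higher number from compound 1 to compound 3 (1.00 log units; beyond the scatter). For compound 2 the result is only a limit of the assay, (the limit of > 5000 nM in this assay, at which 1 of the 3 values shown sits).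

Compound 4, `CCCCCCCC/C=C/CCCCCCCC(=O)Nc1c(C)cccc1OCC`, has not yet been measured. Compared with compound 1 the change is a group of 10 heavy atoms (9 carbon, 1 oxygen; one six-membered aromatic ring of carbon only) in place of a group of 8 heavy atoms (8 carbon; one six-membered aromatic ring of carbon only), on an amide-type nitrogen. Within the data shown here, only one measured step touches the same place: a 10-fold higher number from compound 1 to compound 3 (1.00 log units; beyond the scatter). That step brought in a nitro group, which compound 4 does not carry, so it gives weak guidance for the ethoxy and methyl substitution pattern. The expectation is therefore a change within the scatter in this assay, a 1.3-fold lower number from compound 1 to compound 4 (0.12 log units; within the scatter). Compound 4 is expected to give about 900 nM, between 300 nM and 3000 nM.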

Compound 4, half-maximal inhibitory concentration: 15 nM
Estimate against measurement, compound 4: 60-fold (1.78 log units) above; the whole stated range lies above it.
By their numbers in this assay, from the lowest: compound 4; then compound 1; then compound 3.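

In this assay, the group on the amide-type nitrogen proves able to lower the number sharply, not only to raise it: an 80-fold lower number from compound 1 to compound 4 (1.90 log units; beyond the scatter). Among these compounds, the same place also spans a much wider range than the earlier compounds showed, since a 10-fold higher number from compound 1 to compound 3 (1.00 log units; beyond the scatter) and an 800-fold lower number from compound 3 to compound 4 (2.90 log units; beyond the scatter). Compound 2 is a limit of the assay, so the steps to it cannot be read: the limit of > 5000 nM in this assay, at which 1 of the 4 values shown sits.

Nothing measured among these compounds tells which feature of the change accounts for the lower number in compound 4. As far as these compounds go, it remains open whether the ethoxy or the methyl matters more, and how a group carrying an amine or a carboxylic acid would fare at this same place.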